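Cyclopentyl for cyclohexyl on the shared core

This account rests on a few compounds, and the source may have more. Where it says the series, first, only, none or still open, it means among the compounds named here.

Measured in a functional assay on KB cells (Homo sapiens) for cytotoxicity, read by MTT assay, with a stated time of 72 h; on this read-out higher numbers stand for an effect only at larger amounts of compound and lower numbers for an effect already at smaller amounts:
compound 1 `O=c1cc(NC2CC2)cc(-c2ccccc2)o1`: > 30 uM
compound 2 `COc1ccc(Nc2cc(C3CCCCC3)oc(=O)c2)cc1`: 8.32 uM
compound 3 `O=c1cc(NC2CCCCC2)cc(-c2ccccc2)o1`: 16 uM

The value of compound 1 is a limit of the assay, (the limit of > 30 uM in this assay, at which 1 of the 3 values shown sits). Compound 2 and compound 3 lie within the scatter of each other, so no order between them can be read. Among the measured compounds shown here, the only measured step, an at least 1.8-fold lower number from compound 1 to compound 3 (0.27 log units; that floor lies within the scatter), changes a ring on the nitrogen and starts from a limit.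

Compound 4 `COc1ccc(Nc2cc(C3CCCC3)oc(=O)c2)cc1` differs from compound 2 by cyclopentyl in place of cyclohexyl on an aromatic carbon. For the measured compounds named here, no measured step changes the ring on the aromatic carbon, so no direction is indicated; the expected step in this assay, a 1.0-fold lower number from compound 2 to compound 4 (0.00 log units; within the scatter), is none beyond the scatter. Compound 4 is therefore estimated at 8.3 uM, between 4 uM and 17 uM.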

Compound 4, concentration for half-maximal effect: 8.38 uM
Beside the measured number, compound 4's estimate is 1.0-fold (0.00 log units) below it; measured number inside the range.
By their numbers in this assay, from the lowest: compounds 2, 4 and 3 (each within the scatter of the next). At a limit, above all of these: compound 1.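

Among the compounds shown here, this is the first step that touches the ring on the aromatic carbon next to the ring oxygen: in this assay, the change gives a 1.0-fold higher number from compound 2 to compound 4 (0.00 log units; within the scatter). With the rest of the shared core held constant, cyclopentyl and cyclohexyl therefore cannot be told apart at this position. Nothing shown accounts for this result.

From the compounds shown here alone, it remains open whether an amine such as piperidinyl, a carboxylic acid or a longer alkyl chain at this position would shift the number beyond the scatter. Also open, going by these compounds, is whether the same ring swap gives the same result with a different group on the nitrogen.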